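The source may hold more compounds than are shown below. What is called first, only, known or untested is meant among the compounds shown, and "the series" means these compounds.

Series in a functional assay on NALM-6 cells (Homo sapiens) for cytotoxicity, with a stated time of 72 h; a lower number here means that less compound is needed, a higher number that more compound is needed for the effect:
- compound 1 `C=C[C@@](C)(/C=C/c1ccc(OS(=O)(=O)C(F)(F)F)cc1)CCC=C(C)C`: > 43400 nM (a limit)
- compound 2 `C=C[C@@](C)(/C=C/c1ccc(O)cc1)CC/C=C/C(=O)c1ccccc1`: > 43400 nM (a limit)
- compound 3 `C=C[C@@](C)(/C=C/c1ccc(O)c(C=O)c1)CCC=C(C)C`: 11200 nM

Going by the values given here, compound 3, at 11200 nM, holds the only actual number in this assay. The other two compounds give no number and stand at the limit of > 43400 nM in this assay, at which 2 of the 3 values shown sit.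

Compound 4 `C=C[C@@](C)(/C=C/c1ccc(O)c(/C=C/C(=O)OCC)c1)CCC=C(C)C` keeps the core of compound 3 but has 2-(ethoxycarbonyl)ethenyl in place of formyl on an aromatic carbon, ortho to a hydroxy group (2-(ethoxycarbonyl)ethenyl in place of formyl on an aromatic carbon). Among the compounds with values here, no measured pair tests this change, so the expectation is tentative: a small move toward a higher number, possibly no larger than the usual scatter. The expected step is a 1.3-fold higher number from compound 3 to compound 4 (0.13 log units; within the scatter). For compound 4 the estimated value is 15000 nM, with an expected range of 6000 nM to 40000 nM.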

Compound 4, half-maximal effective concentration: 20900 nM
Compound 4: middle estimate off by 1.4-fold (0.14 log units), on the low side, within the range that was stated.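

In this assay, 2-(ethoxycarbonyl)ethenyl in place of formyl on an aromatic carbon, ortho to a hydroxy group, gives a 1.9-fold higher number from compound 3 to compound 4 (0.27 log units; within the scatter), so this position carries the longer group with no step beyond the scatter. Compound 4 therefore also gives an actual number, while the remaining values are a limit and not numbers: the limit of > 43400 nM in this assay, at which 2 of the 4 values shown sit.

As far as these compounds go, whether a carboxylic acid in place of the ethyl ester, an amine or a saturated chain at this position would keep a measurable number remains open. Also open, from the compounds shown here alone, is what the hydroxy group itself contributes.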